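Swapping a Tetrazole for an Imidazole on the Sulfur

A few compounds are considered here, and "the series" means these few. Any claim that something is new, unique, unknown or untested is made for them only; others in the source may bear on it.

Compound 1 `Cc1ccc2oc(SCC(=O)Nc3ccc(-c4nc(-c5ccccc5)c(-c5ccccc5)n4C)cc3)nc2c1` gives 22.4 ug/mL in a functional assay on MCF7 cells (Homo sapiens) for cytotoxicity, read by MTT assay, with a stated time of 24 h; a higher number here means a weaker inhibitor, a lower number a stronger inhibitor. Compound 2 `Cn1cnnc1SCC(=O)Nc1ccc(-c2nc(-c3ccccc3)c(-c3ccccc3)n2C)cc1` gives 3.2 ug/mL in this assay. Compound 3 `Cn1nnnc1SCC(=O)Nc1ccc(-c2nc(-c3ccccc3)c(-c3ccccc3)n2C)cc1` gives 4.5 ug/mL in this assay.

Among the three measured numbers, compound 3 stands second highest: its nearest neighbour is compound 2, whose value lies within the usual scatter of it, while compound 1 sits clearly higher. The next compound, compound 4 `Cn1ccnc1SCC(=O)Nc1ccc(-c2nc(-c3ccccc3)c(-c3ccccc3)n2C)cc1`, has not been measured. It differs from compound 3 in one place: 1-methyl-1H-imidazol-2-yl in place of 1-methyl-1H-tetrazol-5-yl on a sulfur.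

Two kinds of measured step bear on this change. Replacing the large bicyclic group of compound 1 by a small five-membered ring gave a 7.0-fold lower number from compound 1 to compound 2 (0.85 log units; beyond the scatter) and a 5.0-fold lower number from compound 1 to compound 3 (0.70 log units; beyond the scatter). Exchanging one small five-membered ring for another gave a 1.4-fold higher number from compound 2 to compound 3 (0.15 log units; within the scatter), which is within the scatter. The change to compound 4 is of the second kind, a small ring traded for a small ring, so no step beyond the scatter is expected in this assay, in either direction.

Compound 4 is therefore expected to give about 5 ug/mL, with a likely range from 2 ug/mL to 12 ug/mL, a step of a 1.1-fold higher number from compound 3 to compound 4 (0.05 log units; within the scatter) that is estimated to stay within the scatter.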

Compound 4, half-maximal inhibitory concentration: 46.5 ug/mL
The estimate for compound 4 lay 9.3-fold (0.97 log units) below the measured number, and the stated range ends below it.
By their numbers in this assay, from the lowest: compounds 2 and 3 (each within the scatter of the next); then compound 1; then compound 4.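

In this assay the small rings on the sulfur turn out not to be interchangeable: putting 1-methyl-1H-imidazol-2-yl in place of 1-methyl-1H-tetrazol-5-yl gives a 10-fold higher number from compound 3 to compound 4 (1.01 log units; beyond the scatter) and putting it in place of 4-methyl-4H-1,2,4-triazol-3-yl gives a 15-fold higher number from compound 2 to compound 4 (1.16 log units; beyond the scatter) even though the earlier exchange of one small ring for another stayed within the scatter (a 1.4-fold higher number from compound 2 to compound 3 (0.15 log units; within the scatter)). A small ring on the sulfur therefore no longer goes with a low number on its own, since the large 5-methyl-1,3-benzoxazol-2-yl group of compound 1 now lies on the stronger side, with a 2.1-fold higher number from compound 1 to compound 4 (0.32 log units; beyond the scatter) as the step. The rings of compound 3 and compound 4 match in heavy atoms and in net charge and differ in their counts of carbon, nitrogen and hydrogen-bond acceptors, but no measurement here links the jump to any of these differences.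

On these data alone, it remains open whether the high number belongs to the imidazole ring as a whole or would change with a different group on that ring, such as an amine or a carboxylic acid in place of the methyl. As far as these compounds go, it is equally open where a six-membered pyridine ring on the sulfur would fall relative to these four compounds.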